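Adding a Fluoro to Compound 2, Already at the Limit

The compounds below may be only part of what the source reports. "The series", "measured", "known", "first", "only" and "open" are said of these compounds alone.

Measured so far:
compound 1 `Fc1cc(-c2nnc3n2N=C(c2ccc(Cl)cc2)CS3)c(Cl)cc1Cl` — 5350 nM
compound 2 `Fc1cc(-c2nnc3n2N=C(c2ccc(Cl)cc2Cl)CS3)c(Cl)cc1Cl` — > 100000 nM

Of the compounds shown here, two have been measured in a functional assay on OVCAR-4 cells (Homo sapiens) for antiproliferative activity, read by sulforhodamine B assay, with a stated time of 48 h; a higher number here means a weaker inhibitor of growth, a lower number a stronger inhibitor of growth. Compound 1 gives 5350 nM. Compound 2 gives only a limit of the assay, and its entry is the limit of > 100000 nM in this assay, at which 1 of the 2 values shown sits. Within the data shown here, the one measured step, an at least 18-fold higher number from compound 1 to compound 2 (1.27 log units; beyond the scatter), is a chloro in place of hydrogen on an aromatic carbon.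

Compound 3 `Fc1cc(C2=Nn3c(nnc3-c3cc(F)c(Cl)cc3Cl)SC2)c(Cl)cc1Cl` differs from compound 2 by fluoro in place of hydrogen on an aromatic carbon. Among the measured compounds shown here, no measured step adds a fluoro, so none bears directly on this change; the only measured step, an at least 18-fold higher number from compound 1 to compound 2 (1.27 log units; beyond the scatter), merely shows that compound 2 already sits at the limit in this assay. Compound 3 is therefore expected to stay at or near that limit, and a step that the limit leaves unreadable from compound 2 to compound 3 is expected to be small. Compound 3 is estimated at 150000 nM, with a range from 30000 nM to 600000 nM, and the assay is expected most likely to report only a limit again.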

Compound 3, concentration for 50% growth inhibition: 34500 nM
The estimate for compound 3 lay 4.3-fold (0.64 log units) above the measured number; measured number inside the range.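

In this assay, a fluoro on an aromatic carbon, ortho to a chloro group and para to a chloro group, turns a compound held at a limit into one with a measured number, with an at least 2.8-fold lower number from compound 2 to compound 3 (0.46 log units; beyond the scatter). On these data alone, the full size of this step stays unknown, since the entry for compound 2 is only a limit: the limit of > 100000 nM in this assay, at which 1 of the 3 values shown sits.
The fluoro does not make up the whole loss, however: 2,4-dichloro-5-fluorophenyl in place of 4-chlorophenyl still leaves a 6.4-fold higher number from compound 1 to compound 3 (0.81 log units; beyond the scatter).

The compounds shown leave open whether a fluoro at this place would lower the number to a similar degree on the 4-chlorophenyl of compound 1, which carries no second chloro. They also leave open whether the effect is specific to fluoro, or whether a chloro, a methoxy or an amine at the same place would give a measured number too.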